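The source may report more compounds than this note shows. Statements on the series, on what has been measured and on what is new or still open speak of the compounds shown alone.

Measured so far:
- Compound 1, `COc1ccc(-c2cnc(NC(=O)C3CCNCC3)n2C)cc1`: in a toxicity assay on THP-1 cells (Homo sapiens) for inhibition (on this read-out lower numbers stand for higher toxicity in this test and higher numbers for lower toxicity in this test), compound 1 gives > 100000 nM, which is a limit of the assay and not a number.
- Compound 2, `COc1ccc(-c2cnc(NC(=O)C3CCCCC3)n2C)cc1`: in this assay compound 2 gives > 100000 nM, again a limit of the assay rather than a number.

Compound 2 thus stands only at a limit; nothing in this assay places it on a scale relative to anything else. Within the data shown here, the single measured step, a step that the two limits leave unreadable from compound 1 to compound 2, runs between two limits and cannot be read, so no size is available for exchanging the group on the carbonyl carbon. Among the measured compounds shown here, every value so far sits at the limit of > 100000 nM in this assay, at which 2 of the 2 values shown sit.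

Compound 3, `COc1ccc(-c2cnc(NC(=O)c3ccccc3Cl)n2C)cc1`, carries the change (2-chlorophenyl in place of cyclohexyl on a carbonyl carbon). For the measured compounds named here, no readable measured step bears on this exchange; the only comparison at hand is the unreadable one. With every result so far at the limit and no size known for any change at the carbonyl carbon, the expectation for this assay is a result near the limit again, with no direction that can be read beyond the scatter. The expected step is a number no higher from compound 2 to compound 3 (the limit leaves the size open). Compound 3 is estimated at 100000 nM, with a range from 30000 nM to 300000 nM, and most likely reported once more only as a limit.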

Compound 3, half-maximal cytotoxic concentration: > 50000 nM
Compound 3 ended at the assay's limit; the forecaster's own chance of this, stated with the estimate: 75%; the middle value lies beyond the limit too.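

In this assay compound 3 gives > 50000 nM, which is a limit of the assay and not a number. The steps joining compound 3 to compound 1 and compound 2 therefore cannot be read. The compounds shown leave open how piperidin-4-yl, cyclohexyl and 2-chlorophenyl on the carbonyl carbon would compare on a measured scale.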